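The source may hold more compounds than are shown below. What is called first, only, known or untested is meant among the compounds shown, and "the series" means these compounds.

compound 1 `CCC1C(=O)N(C)c2cnc(-n3ccc4cc(C(=O)NC)ccc43)nc2N1c1ccn(C)n1`: 35400 nM
compound 2 `CC[C@@H]1C(=O)N(C)c2cnc(Nc3ccc(S(=O)(=O)NCCCO)cc3)nc2N1C1CCCC1`: 363 nM

Both compounds were tested in a functional assay on MCF7 cells (Homo sapiens) for antiproliferative activity, read by CCK-8 assay, with a stated time of 72 h; on this read-out higher numbers stand for weaker inhibition of growth and lower numbers for stronger inhibition of growth. Of the two numbers, compound 1 holds the higher one, 35400 nM, which makes it the weaker growth inhibitor. By contrast, compound 2 stands far lower at 363 nM, a gap beyond the usual scatter.

Still unmeasured is compound 3 `CCNC(=O)c1ccc2c(ccn2-c2ncc3c(n2)N(c2ccn(C)n2)C(CC)C(=O)N3C)c1`, which keeps the core of compound 1 and alters only its amide side group, turning methylcarbamoyl into ethylcarbamoyl. The difference is methyl in place of hydrogen on a saturated chain carbon bound to an amide-type nitrogen.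

Among the compounds with values here, no two measured compounds differ in just one place, so the data offer no direct precedent for a step of this kind. Compound 2 differs from compound 1 in more than one place and is a poor guide here. With compound 1 at 35400 nM as the starting point, no step beyond the scatter is expected in this assay, in either direction. The expected change is a 1.2-fold lower number from compound 1 to compound 3 (0.07 log units; within the scatter). For compound 3 the estimated value is 30000 nM, with an expected range from 12000 nM to 75000 nM.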

Compound 3, concentration for 50% growth inhibition: 13200 nM
Estimate against measurement, compound 3: 2.3-fold (0.36 log units) above; low and high end bracket the measured number.
By their numbers in this assay, from the lowest: compound 2; then compound 3; then compound 1.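

In this assay the change from methylcarbamoyl to ethylcarbamoyl gives a 2.7-fold lower number from compound 1 to compound 3 (0.43 log units; beyond the scatter) and so shows that this amide side group is not indifferent to a single added methyl, since that one carbon moves the number further than repeated measurements usually would. The step is modest, but it runs toward stronger inhibition of growth, so on the core of compound 1 this position accepts the slightly longer ethyl group with no loss in this cell read-out. Nothing available gives a measured property that would account for this step, so it stands here as an observation only.

Going by these compounds, a single step cannot show a trend, so it remains open whether a longer chain such as propyl, or a branched group such as isopropyl, would carry the number further down, leave it level or reverse the step. The compounds shown also leave open how an amine or a carboxylic acid at the end of this chain would read, and whether the same methyl would give a similar step on another core.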